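The source may hold more compounds than are shown below. What is called first, only, known or untested is meant among the compounds shown, and "the series" means these compounds.

Measured compounds:
compound 1 `Nc1nc(Cl)c2ncn(Cc3ccc(CCl)cc3)c2n1`, 77600 nM
compound 2 `ClCc1cccc(Cn2cnc3c(Cl)nc(Cl)nc32)c1`, 22400 nM
compound 3 `ClCc1ccc(Cn2cnc3c(Cl)nc(Cl)nc32)cc1`, 58900 nM

In a functional assay on NCI-H23 cells (Homo sapiens) for cytotoxicity, read by sulforhodamine B assay, with a stated time of 48 h (a higher number here means that more compound is tolerated, a lower number that less compound is tolerated), compound 2 gives 22400 nM, the lowest of the three numbers; compound 3 and compound 1 both stand beyond the scatter above it. Compound 2 and compound 3 are built from the same atoms joined differently; the difference between the two cores is not broken down here. From compound 3 to compound 1 the change is amino in place of chloro on an aromatic carbon, and it produced a 1.3-fold higher number from compound 3 to compound 1 (0.12 log units; within the scatter).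

Compound 4 `Nc1nc(Cl)c2ncn(Cc3cccc(CCl)c3)c2n1` is not yet measured. It differs from compound 2 by amino in place of chloro on an aromatic carbon. The place is described in the same words as for the earlier pair, so this is the same change made on the other core. For compound 4 in this assay a step of about a 1.3-fold higher number from compound 2 to compound 4 (0.11 log units; within the scatter) is expected, because a 1.3-fold higher number from compound 3 to compound 1 (0.12 log units; within the scatter) was small and the same change is repeated here. Compound 4 is therefore estimated at 29000 nM, with a plausible range from 12000 nM to 70000 nM.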

Compound 4, concentration lethal to 50% of the cells: 26900 nM
Beside the measured number, compound 4's estimate is 1.1-fold (0.03 log units) above it, and the stated range covers the measured number.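

In this assay, amino in place of chloro on an aromatic carbon gives a 1.2-fold higher number from compound 2 to compound 4 (0.08 log units; within the scatter), and this step agrees with the one seen on the other core: the same change on two cores in this assay, a 1.3-fold higher number (0.12 log units; within the scatter) from compound 3 to compound 1 and a 1.2-fold higher number (0.08 log units; within the scatter) from compound 2 to compound 4, 1.1-fold (0.04 log units) apart, within the scatter of two such steps. On these two cores the exchange therefore carries over as a step that stays within the scatter each time, so it separates neither compound 4 from compound 2 nor compound 1 from compound 3. This does not show that the exchange would stay within the scatter on any other core or in any other cell line, and two pairs with steps this small fix neither a reliable size nor a reliable direction for it.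

Still open, on these data alone, is whether a different group on this aromatic carbon, such as a methylamino, hydroxyl or methoxy group, would give a step beyond the scatter. Also open, as far as these compounds go, is how far the numbers depend on the chloromethyl group, which a methyl or hydroxymethyl group in its place would test.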